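The source may report more compounds than this note shows. Statements on the series, on what has been measured and on what is new or still open speak of the compounds shown alone.

Compound 1 `O=C(Nc1ccc(C(F)(F)F)cc1)Nc1cc2ncncc2cc1OCc1cccc(F)c1`: 3800 nM
Compound 2 `O=C(Nc1ccc(C(F)(F)F)cc1)Nc1cc2ncncc2cc1OCc1cccc(Cl)c1`: 3400 nM

In a functional assay on GBM1 cells (Homo sapiens) for antiproliferative activity, read by WST assay, with a stated time of 72 h (a higher number here means a weaker inhibitor, a lower number a stronger inhibitor), compound 1 gives 3800 nM and stands level with compound 2, the gap being a 1.1-fold lower number from compound 1 to compound 2 (0.05 log units; within the scatter) between them. Compound 3 `O=C(Nc1ccccc1F)Nc1cc2ncncc2cc1OCc1cccc(F)c1` carries 2-fluorophenyl in place of 4-(trifluoromethyl)phenyl on an amide-type nitrogen. Among the measured compounds shown here, the one measured step, chloro in place of fluoro on an aromatic carbon, was a 1.1-fold lower number from compound 1 to compound 2 (0.05 log units; within the scatter) and does not touch this place. Nothing measured therefore fixes size or direction in this assay, and no firm shift beyond the scatter is expected. The expected step is a 1.2-fold higher number from compound 1 to compound 3 (0.07 log units; within the scatter). Compound 3 is estimated at 4500 nM, with an expected range of 1500 nM to 13000 nM.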

Compound 3, half-maximal inhibitory concentration: 8000 nM
The estimate for compound 3 lay 1.8-fold (0.25 log units) below the measured number; low and high end bracket the measured number.
By their numbers in this assay, from the lowest: compounds 2 and 1 (each within the scatter of the next); then compound 3.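

In this assay, the group on the amide-type nitrogen turned out to be a place where a change registers, which the earlier chloro-for-fluoro pair could not show: 2-fluorophenyl in place of 4-(trifluoromethyl)phenyl gave a 2.1-fold higher number from compound 1 to compound 3 (0.32 log units; beyond the scatter). Among the compounds shown here, the step is modest, yet it is the first one here beyond the scatter. No evidence is available to explain it. Since the trifluoromethyl group and the fluoro group changed together, the compounds shown leave their separate contributions open. A plain phenyl group at this place could help separate them.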